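Trading a fluorobenzyl amide for a phenylcyclopropyl amide

The source may report more compounds than this note shows. Statements on the series, on what has been measured and on what is new or still open speak of the compounds shown alone.

The measured compounds are:

Compound 1, `Cc1ccc2nc(N3CCNC(C)C3)nc(NCc3ccc(C(=O)NCc4ccc(F)cc4)cc3)c2c1`, 1400 nM
Compound 2, `Cc1ccc2nc(N(C)C)nc(NCc3ccc(C(=O)NCc4ccc(F)cc4)cc3)c2c1`, 1100 nM
Compound 3, `CN(C)c1nc(NCc2ccc(NC(=O)c3ccncc3)cc2)c2ccccc2n1`, 11000 nM

In a functional assay on SW480 cells (Homo sapiens) for inhibition, read by luminescence and resazurin assay, with a stated time of 3 days (a lower number here means a stronger inhibitor, a higher number a weaker inhibitor), compound 2 gives the lowest of the three numbers. Its nearest neighbour is compound 1, and the step of a 1.3-fold lower number from compound 1 to compound 2 (0.10 log units; within the scatter) is within the scatter, so the two cannot be ordered. Compound 3 stands furthest away, with compound 3 at 11000 nM against compound 2 at 1100 nM, a gap beyond the scatter, and it differs from compound 2 at several places, so nothing about any single change can be read from that gap.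

Compound 4, `Cc1ccc2nc(N(C)C)nc(NCc3ccc(C(=O)N[C@H]4C[C@@H]4c4ccccc4)cc3)c2c1`, has not been measured. It differs from compound 2 by 2-phenylcyclopropyl in place of 4-fluorobenzyl on an amide-type nitrogen. No measured step touches the amide-type nitrogen; the one step shown, from compound 1 to compound 2, sits on an aromatic carbon of the core and is itself within the scatter. Among the measured compounds shown here, there is thus no precedent in these data for the change in question. The estimate for compound 4 in this assay rests only on compound 2 at 1100 nM, and the step of a 1.4-fold higher number from compound 2 to compound 4 (0.13 log units; within the scatter) is expected to stay near the scatter, in either direction. Compound 4 is estimated at 1500 nM, with a range from 450 nM to 5000 nM.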

Compound 4, half-maximal inhibitory concentration: 2400 nM
The estimate for compound 4 lay 1.6-fold (0.20 log units) below the measured number; the range from low to high includes it.
By their numbers in this assay, from the lowest: compounds 2, 1 and 4 (each within the scatter of the next, the first and the last beyond it); then compound 3.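

Among the compounds shown here, no earlier step touched the amide-type nitrogen, and the first one read there in this assay, a 2.2-fold higher number from compound 2 to compound 4 (0.34 log units; beyond the scatter), lies beyond the scatter, though it is modest. For the compounds shown here, this shows that the number responds to the group on this nitrogen, and that 2-phenylcyclopropyl in place of 4-fluorobenzyl gives a weaker inhibitor, whereas the only earlier single-place step, on an aromatic carbon of the core, could not be ordered. Nothing measured here bears on why the number moved.

Going by these compounds, it remains open whether the step follows from the loss of the fluorine, the three-membered ring or the particular arrangement of the two defined stereocentres. A plain benzyl group, the opposite stereoisomer of 2-phenylcyclopropyl, or a longer chain ending in an amine on this nitrogen would help to separate these possibilities.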